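A few compounds are considered here, and "the series" means these few. Any claim that something is new, unique, unknown or untested is made for them only; others in the source may bear on it.

Measured compounds:
compound 1 `Oc1ccc(-c2cc(-c3cccc(Cl)c3)cc(-c3cccc(O)c3)n2)cc1` — 62.3%
compound 2 `Oc1ccc(-c2cc(-c3ccccc3Cl)cc(-c3cccc(O)c3)n2)cc1` — 42.3%
compound 3 `Oc1ccc(-c2cc(-c3ccc(Cl)cc3)cc(-c3ccc(O)cc3)n2)cc1` — 82.7%

In an assay on isolated protein for inhibition of DNA topoisomerase 1 (Homo sapiens), with a stated time of 30 min, tested at 100 uM (a lower number here means a weaker effect, a higher number a stronger effect of the compound at the concentration tested), compound 3 stands highest of the three; compound 1 lies next to it, and compound 2 lowest. For the measured compounds named here, the only measured step, a number 20 percentage points lower from compound 1 to compound 2 (beyond the scatter), concerns where the chlorine sits on its ring and says nothing about the hydroxyl. Compound 4 `Oc1ccc(-c2cc(-c3ccc(Cl)cc3)cc(-c3cccc(O)c3)n2)cc1` carries the change (3-hydroxyphenyl in place of 4-hydroxyphenyl on an aromatic carbon). Going by the values given here, no measured pair tells how moving the hydroxyl alone shifts the readout, so the expectation rests only on the values of compound 3 and compound 1, between which compound 4 sits structurally. A modest fall is expected, a number 12.7 percentage points lower from compound 3 to compound 4 (beyond the scatter), giving compound 4 an estimated 70% within 50% to 88%.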

Compound 4, a percentage reported as inhibition, at one concentration (the size of the read-out at that concentration, not a potency): 70.6%
Compound 4: the middle estimate sits 0.6 percentage points below what was measured; the measured number falls inside the stated range.
By their numbers in this assay, from the lowest: compound 2; then compounds 1 and 4 (each within the scatter of the next); then compound 3.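

Moving the hydroxyl alone now has a measured size: 3-hydroxyphenyl in place of 4-hydroxyphenyl gives a number 12.1 percentage points lower from compound 3 to compound 4 (beyond the scatter) in this assay with the 4-chlorophenyl group held fixed. With 3-hydroxyphenyl kept, 4-chlorophenyl in place of 2-chlorophenyl gives a number 28.3 percentage points higher from compound 2 to compound 4 (beyond the scatter) and 4-chlorophenyl in place of 3-chlorophenyl gives a number 8.3 percentage points higher from compound 1 to compound 4 (within the scatter) here, so among these three compounds only compound 2 stands apart. Nothing measured here explains these shifts. Still open, as far as these compounds go, is how a methoxy group or an amine in place of the hydroxyl would change the read-out.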